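Removing the para-chloro from a sigma-1 oxadiazolone ligand

The compounds below may be only part of what the source reports. "The series", "measured", "known", "first", "only" and "open" are said of these compounds alone.

Measured compounds:
Compound 1, `CN(CCCCn1nc(-c2ccccc2)oc1=O)Cc1ccc(Cl)cc1`: 18.7 nM
Compound 2, `CN(CCCCN1CCCCC1=O)Cc1ccccc1`: > 3000 nM

Compound 1 is the only one of the two measured compounds for which an assay on cell membranes from Cerebral cortex for displacement of a labelled ligand from Sigma non-opioid intracellular receptor 1 (Cavia porcellus), read by scintillation counting, with a stated time of 120 min (a higher number here means a weaker inhibitor, a lower number a stronger inhibitor), returns a number, 18.7 nM. For compound 2 the result, > 3000 nM, is a limit of the assay and not a number (the limit of > 3000 nM in this assay, at which 1 of the 2 values shown sits). Compound 1 and compound 2 differ in more than one place, so their values show only that one is measured and the other is not. Compound 3, `CN(CCCCn1nc(-c2ccccc2)oc1=O)Cc1ccccc1`, is compound 1 with hydrogen in place of chloro on an aromatic carbon. For the measured compounds named here, no step between measured compounds isolates this change. The expected step from compound 1 to compound 3 in this assay is estimated as a 2.9-fold higher number from compound 1 to compound 3 (0.47 log units; beyond the scatter), a modest loss somewhat beyond the usual scatter. Compound 3 is therefore expected to give 55 nM in this assay, estimated within a range from 15 nM to 200 nM.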

Compound 3, inhibition constant: 5.2 nM
The estimate for compound 3 lay 11-fold (1.02 log units) above the measured number; the whole stated range lies above it.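

In this assay, replacing chloro with hydrogen on the aromatic carbon, para to a large group, gives a 3.6-fold lower number from compound 1 to compound 3 (0.56 log units; beyond the scatter), the first step shown that isolates a single change at this position. Within this one pair, then, the chloro is not needed for strong displacement of the labelled ligand, and the plain benzyl compound gives the lower number. Nothing among the data shown accounts for the size or direction of this step.

The compounds shown leave open how a fluoro, methyl, methoxy or trifluoromethyl group would read at this same place. They also leave open whether the step from 4-chlorobenzyl to benzyl would hold with a shorter or longer chain, or with an ethyl group in place of the methyl on the amine.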